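Ring closure on the chain of compound 3

The compounds below may be only part of what the source reports. "The series", "measured", "known", "first", "only" and "open" are said of these compounds alone.

For the measured compounds named here, compound 3, with structure `CCCC[C@@H](NC(=O)c1nccs1)c1cnc(Nc2ccc(C)nc2)c(Cl)c1`, sits second highest of the three numbers known in a functional assay on HEK293 cells for negative allosteric modulation of metabotropic glutamate receptor 5 (Homo sapiens), read by HTRF and inositol phosphate accumulation; on this read-out lower numbers stand for stronger inhibition and higher numbers for weaker inhibition: compound 3 gives 30.9 nM, while compound 1 (`CCC[C@@H](NC(=O)c1nccs1)c1cnc(Nc2ccc(C)nc2)c(Cl)c1`) gives 8.2 nM and compound 2 (`CCC[C@H](NC(=O)c1nccs1)c1cnc(Nc2ccc(C)nc2)c(Cl)c1`) gives 978 nM. Compound 4 (`Cc1ccc(Nc2ncc([C@H](NC(=O)c3nccs3)C3CCCC3)cc2Cl)cn1`) differs from compound 3 by cyclopentyl in place of butyl on a saturated chain carbon bound to an amide-type nitrogen and an aromatic carbon. The step from compound 1 to compound 3 , a 3.8-fold higher number from compound 1 to compound 3 (0.58 log units; beyond the scatter), shows that lengthening this chain weakened inhibition modestly, and the step of a 120-fold higher number from compound 1 to compound 2 (2.08 log units; beyond the scatter) shows that configuration at this carbon matters greatly, though compound 4 keeps the configuration of compound 3. The change to a ring is expected to shift this assay only modestly, a 1.5-fold lower number from compound 3 to compound 4 (0.19 log units; within the scatter). Compound 4 is therefore estimated at 20 nM, within 6 nM to 70 nM.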

Compound 4, half-maximal inhibitory concentration: 16.6 nM
Beside the measured number, compound 4's estimate is 1.2-fold (0.08 log units) above it; low and high end bracket the measured number.
By their numbers in this assay, from the lowest: compound 1; then compounds 4 and 3 (each within the scatter of the next); then compound 2.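

Set on the saturated chain carbon bound to an amide-type nitrogen and an aromatic carbon, a cyclopentyl ring cannot be told apart from butyl in this assay, with a 1.9-fold lower number from compound 3 to compound 4 (0.27 log units; within the scatter). So this position accepts a ring as well as an open chain. Propyl keeps a modest edge over the ring, with a 2.0-fold higher number from compound 1 to compound 4 (0.31 log units; beyond the scatter).

On these data alone, whether a cyclopropyl, a cyclohexyl or an oxygen-containing tetrahydropyranyl ring would read the same remains open. Nothing available explains how ring and chain compare.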